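Coumarate ester geometry in a labdane-type cytotoxicity series

The source may report more compounds than this note shows. Statements on the series, on what has been measured and on what is new or still open speak of the compounds shown alone.

Measured:
compound 1 `C=CC(=C)CC[C@@H]1[C@@]2(C)CCC[C@](C)(COC(=O)/C=C/c3ccc(O)cc3)[C@@H]2CC[C@@]1(C)O` gives 11800 nM
compound 2 `C=C1CC[C@@H]2[C@](C)(CCC[C@]2(C)C(=O)O)[C@H]1CC/C(C)=C/CO` gives > 40000 nM
compound 3 `C=C/C(C)=C/C[C@H]1C(=C)CC[C@@H]2[C@]1(C)CCC[C@]2(C)C=O` gives > 40000 nM

Among the measured compounds shown here, in a functional assay on HL-60 cells (Homo sapiens) for cytotoxicity, read by MTT assay, with a stated time of 48 h (a higher number here means a weaker inhibitor, a lower number a stronger inhibitor), compound 1 is the only member of the series that returns a number. For compound 2 this assay reports only a limit, > 40000 nM. For compound 3 likewise only a limit is reported, > 40000 nM. For the measured compounds named here, two of the three values therefore sit at the limit of > 40000 nM in this assay, at which 2 of the 3 values shown sit, so no measured step is available to calibrate expectations.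

Compound 4 `C=CC(=C)CC[C@@H]1[C@@]2(C)CCC[C@](C)(COC(=O)/C=C\c3ccc(O)cc3)[C@@H]2CC[C@@]1(C)O` is to be measured in this assay. the two compounds have the same atoms and bonds and differ only in configuration as drawn: 1 of 6 stereo elements differ; a double bond is drawn E in compound 1 and Z in compound 4

Going by the values given here, with no measured step touching this kind of change, a step within the usual scatter is expected for the move from compound 1 to compound 4. For compound 4 the expected value is 13000 nM, between 5000 nM and 35000 nM, a step of a 1.1-fold higher number from compound 1 to compound 4 (0.04 log units; within the scatter) from compound 1.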

Compound 4, half-maximal inhibitory concentration: 14100 nM
For compound 4 the middle estimate is 1.1-fold (0.04 log units) below the measured one; low and high end bracket the measured number.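

Among the compounds shown here, the step of a 1.2-fold higher number from compound 1 to compound 4 (0.08 log units; within the scatter) is the first measured step in this assay and it concerns the double bond of the coumarate ester. Drawing that double bond E or Z does not separate the two compounds in this read-out, so at this position the geometry carries no measurable difference.

On these data alone, whether the coumarate ester itself matters remains open. An amide in place of the ester, or a methoxy group in place of the phenol hydroxyl, would bear on that question.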